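This account rests on a few compounds, and the source may have more. Where it says the series, first, only, none or still open, it means among the compounds named here.

Working notes on the series. Compound 1 `CC(=O)c1cc(-c2ccccc2)cc2cc(-c3ccc(F)cc3)[nH]c12` in a functional assay on HeLa cells (Homo sapiens) for cytotoxicity, read by MTT assay, with a stated time of 2 days, tested at 100 uM (a higher number here means a weaker effect of the compound at the concentration tested, a lower number a stronger effect), gives 68.3%. Among the compounds with values here, compound 2 `COc1ccc(-c2cc(C(C)=O)c3[nH]c(-c4ccc(F)cc4)cc3c2)cc1` gives 20.6% in this assay; the one measured step, a number 47.7 percentage points lower from compound 1 to compound 2 (beyond the scatter), is the only change so far that reads beyond the scatter. Compound 3 `CC(=O)c1cc(/C=C/c2ccccc2)cc2cc(-c3ccccc3)[nH]c12` gives 21.3% in this assay. On the numbers shown, compound 3 sits far from compound 1, a gap beyond the scatter, and within the scatter of compound 2, so no order between compound 3 and compound 2 can be read from these two values.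

Compound 4 `CC(=O)c1cc(/C=C/c2ccccc2)cc2cc(-c3ccc(F)cc3)[nH]c12` differs from compound 3 by fluoro in place of hydrogen on an aromatic carbon. Within the data shown here, no measured pair isolates this change: compound 1 already carries the 4-fluorophenyl and compound 3 the phenyl, but the two also differ at the second aryl group, so their gap cannot be assigned to fluoro. Among the measured compounds shown here, the single step on record, a number 47.7 percentage points lower from compound 1 to compound 2 (beyond the scatter), concerns methoxy in place of hydrogen and does not bear on fluoro. With nothing to indicate movement, the expected step of a number 0.7 percentage points higher from compound 3 to compound 4 (within the scatter) is none beyond the scatter.

Compound 4 is therefore estimated at 22% in this assay, with a range from 8% to 45%.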

Compound 4, a percentage reported as activity, at one concentration (the size of the read-out at that concentration, not a potency): 24.3%
Beside the measured number, compound 4's estimate is 2.3 percentage points below it; low and high end bracket the measured number.
By their numbers in this assay, from the lowest: compounds 2, 3 and 4 (each within the scatter of the next); then compound 1.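

In this assay fluoro in place of hydrogen on an aromatic carbon now has a measured pair, a number 3 percentage points higher from compound 3 to compound 4 (within the scatter) and so, with 2-phenylethenyl held in the core, phenyl to 4-fluorophenyl moves the read-out by no more than the scatter. Within the data shown here, with the 4-fluorophenyl held constant, the other aryl position also gains two new comparisons: 2-phenylethenyl in place of phenyl gives a number 44 percentage points lower from compound 1 to compound 4 (beyond the scatter) and counts as large, whereas 2-phenylethenyl in place of 4-methoxyphenyl gives a number 3.7 percentage points higher from compound 2 to compound 4 (within the scatter) and so leaves those two groups unordered, with phenyl the one group of the three at this position that stands apart. Nothing on hand gives a reason for any of these steps.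

Among these compounds, whether fluoro is equally silent when phenyl or 4-methoxyphenyl occupies the other aryl position remains open, since the only fluoro pair carries 2-phenylethenyl. Also open, as far as these compounds go, is whether an amine or a carboxylic acid in place of fluoro, or a longer chain in place of 2-phenylethenyl, would hold the read-out in the range of compound 2, compound 3 and compound 4, and each of these values is a single-concentration read-out rather than a potency.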